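A few compounds are considered here, and "the series" means these few. Any claim that something is new, unique, unknown or untested is made for them only; others in the source may bear on it.

Measured so far in an assay on Sf9 cells for inhibition of protein deacetylase HDAC6 (Homo sapiens), read by fluorescence, with a stated time of 40 min, tested at 100 nM; on this read-out lower numbers stand for less inhibition and higher numbers for more inhibition at the one concentration tested (going by the name of the read-out):
compound 1, `O=C(NO)c1ccc(NCc2nc(-c3ccco3)nn2-c2ccccc2)cc1`: compound 1 gives 59.9%
compound 2, `Cc1ccsc1-c1nc(CNc2ccc(C(=O)NO)cc2)n(-c2ccccc2)n1`: compound 2 gives 72.1%

Compound 2 stands highest of the two numbers; its nearest neighbour is compound 1, and the step between them is a number 12.2 percentage points higher from compound 1 to compound 2 (beyond the scatter). Compound 3, `O=C(NO)c1ccc(NCc2nc(-c3ccccc3Cl)nn2-c2ccccc2)cc1`, is not yet measured. Its change from compound 2 is 2-chlorophenyl in place of 3-methylthiophen-2-yl on an aromatic carbon. Within the data shown here, the one measured step bears on this only loosely: it also swaps the group on the same aromatic carbon, and there it moved the number modestly, beyond the scatter. Among the measured compounds shown here, no measured pair contains 2-chlorophenyl, so the direction of the new step cannot be read from the data. A step of about that size in either direction, or none beyond the scatter, is expected in this assay. The estimate for compound 3 is 65%, with a range of 45% to 85%. The expected step is thus a number 7.1 percentage points lower from compound 2 to compound 3 (within the scatter).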

Compound 3, a percentage reported as inhibition, at one concentration (the size of the read-out at that concentration, not a potency): 75%
For compound 3 the middle estimate is 10 percentage points below the measured one; the range from low to high includes it.
By their numbers in this assay, from the lowest: compound 1; then compounds 2 and 3 (each within the scatter of the next).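

In this assay, the aromatic carbon between two ring nitrogen atoms carries a six-membered aromatic ring of carbon only as well as a five-membered aromatic ring with sulfur, with the exchange giving a number 2.9 percentage points higher from compound 2 to compound 3 (within the scatter) and no separation between the two groups. Measured against furan-2-yl, 2-chlorophenyl gives a number 15.1 percentage points higher from compound 1 to compound 3 (beyond the scatter) and 3-methylthiophen-2-yl gives a number 12.2 percentage points higher from compound 1 to compound 2 (beyond the scatter), so among these three compounds the furan-2-yl compound alone stands apart. Nothing measured here gives a reason for these differences.

Whether the chlorine itself matters remains open, since unsubstituted phenyl is not among the compounds shown. Also open, as far as these compounds go, is whether the number would be higher, lower or level with a non-aromatic group such as a morpholine or a carboxylic acid on this carbon, and how these single-concentration readings would translate into potency.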